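A few compounds are considered here, and "the series" means these few. Any claim that something is new, unique, unknown or untested is made for them only; others in the source may bear on it.

The study concerns a small set of compounds built on one shared core and tested in a functional assay on ECa-109 cells (Homo sapiens) for inhibition, read by MTT assay, with a stated time of 72 h; on this read-out higher numbers stand for weaker inhibition and lower numbers for stronger inhibition. Compound 1 `COc1ccc(-n2cc(CSC(=S)N3CCN(C(=O)OC(C)(C)C)CC3)nn2)cc1` gives in this assay > 128000 nM, which is a limit of the assay and not a number. Compound 2 `CC(C)(C)OC(=O)N1CCN(C(=S)SCc2cn(-c3ccccc3F)nn2)CC1` gives in this assay > 128000 nM, again a limit of the assay. Compound 3 `Fc1ccc(Cn2cc(CSC(=S)N3CCNCC3)nn2)cc1` gives in this assay > 128000 nM, also a limit. Compound 2 thus stands at the limit of > 128000 nM in this assay, at which 3 of the 3 values shown sit, and nothing separates it from the other two measured compounds. Among the compounds with values here, the only step that can be drawn between measured compounds, a step that the two limits leave unreadable from compound 1 to compound 2, is unreadable, since both of its ends sit at the limit of > 128000 nM in this assay, at which 3 of the 3 values shown sit.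

Compound 4 `Cc1ccc(Cn2cc(CSC(=S)N3CCN(C(=O)OC(C)(C)C)CC3)nn2)cc1` differs from compound 2 by 4-methylbenzyl in place of 2-fluorophenyl on an aromatic nitrogen. Within the data shown here, no measured step bears readably on this change; the sole guidance is that every measured compound sits at the limit of > 128000 nM in this assay, at which 3 of the 3 values shown sit. Compound 4 is therefore expected to show no step beyond the scatter, a step that the limit leaves unreadable from compound 2 to compound 4, and most likely to report only a limit. Compound 4 is estimated at 150000 nM, with a range from 30000 nM to 600000 nM.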

Compound 4, half-maximal inhibitory concentration: 47900 nM
For compound 4 the middle estimate is 3.1-fold (0.50 log units) above the measured one; the measured number falls inside the stated range.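

In this assay, the group on the aromatic nitrogen of the five-membered ring proves able to move the read-out off the limit: 4-methylbenzyl in place of 2-fluorophenyl gives an at least 2.6-fold lower number from compound 2 to compound 4 (0.42 log units; beyond the scatter), and 4-methylbenzyl in place of 4-methoxyphenyl gives an at least 2.6-fold lower number from compound 1 to compound 4 (0.42 log units; beyond the scatter). From the compounds shown here alone, both steps start from a limit of the assay and not from a number, so they give only the smallest possible size of the change, and the full size stays unknown. Among the compounds shown, only compound 4 gives a readable number, so this position is the one place where a change has been seen to matter, and the rest of the set offers no second number to compare it with: the limit of > 128000 nM in this assay, at which 3 of the 4 values shown sit.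

The compounds shown leave open whether the gain belongs to the methyl group or to the benzyl form of the substituent, since the change brings in both at once. They also leave open how an unsubstituted benzyl, a 4-chlorobenzyl or a longer chain such as 2-phenylethyl would read at this position. Going by these compounds, compound 4 gives 47900 nM, and whether any of these would differ from that value by more than the scatter remains unknown.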